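Swapping the aryl group on the amide-type nitrogen

The compounds below may be only part of what the source reports. "The series", "measured", "known", "first", "only" and "open" are said of these compounds alone.

In an ADME assay on microsomes from liver (Homo sapiens) for metabolic stability (a lower number here means slower removal, a higher number faster removal of the compound), compound 1 `O=C(N1CCC(c2ccccc2)CC1)N(c1ncccc1Cl)[C@@H]1CCCNC1` gives < 9.3 mL.min-1.g-1 as a limit of the assay, not a number. Compound 2 `O=C(CCc1ccc(-n2nnc3cccnc32)cc1)N(c1ncccc1Cl)[C@@H]1CCCNC1` gives 9.7 mL.min-1.g-1 in this assay. Compound 3 `Cc1nccnc1N(C(=O)N1CCC(c2ccccc2)CC1)[C@@H]1CCCNC1` has 3-methylpyrazin-2-yl in place of the 3-chloropyridin-2-yl of compound 1 on an amide-type nitrogen (3-methylpyrazin-2-yl in place of 3-chloropyridin-2-yl on an amide-type nitrogen). For the measured compounds named here, no measured step bears on this change. The expected at least 1.0-fold higher number from compound 1 to compound 3 (0.03 log units; that floor lies within the scatter) in this assay is none beyond the scatter, with no direction favoured. Compound 3 is estimated at 10 mL.min-1.g-1 with an expected range of 6 mL.min-1.g-1 to 20 mL.min-1.g-1 in this assay.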

Compound 3, intrinsic clearance in microsomes: < 8 mL.min-1.g-1
Compound 3: no number, only a limit; the forecaster's own chance of this, stated with the estimate: 50%; middle value at least 1.2-fold (0.09 log units) from the limit.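

Compound 1 and compound 3 each give only a limit in this assay, not a number, so no step can be read between them. From the compounds shown here alone, whether 3-methylpyrazin-2-yl in place of 3-chloropyridin-2-yl on an amide-type nitrogen changes the read-out at all stays open.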